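Swapping the Aromatic Methyl for Chloro

The source may hold more compounds than are shown below. What is called first, only, known or untested is meant among the compounds shown, and "the series" means these compounds.

The series shares one core, shown by compound 1 `CC(C(=O)N1CCN(c2ccccc2)CC1)N1C(=O)CCC1=O`, and the comparisons rest on a functional assay on the whole organism (strain Swiss) with Mus musculus as the target, in the maximal electroshock model, with a stated time of 0.25 h, at a dose of 100 mg/kg by the intraperitoneal route; on this read-out higher numbers stand for a stronger effect at the one dose given and lower numbers for a weaker effect. In this assay compound 1 gives 50%. Compound 2 `Cc1cccc(N2CCN(C(=O)C(C)N3C(=O)CCC3=O)CC2)c1` carries a methyl on an aromatic carbon, and in this assay compound 2 gives 0%, the lowest of the two numbers shown; the only step recorded, a number 50 percentage points lower from compound 1 to compound 2 (beyond the scatter), is therefore a large fall. Compound 3 `CC(C(=O)N1CCN(c2cccc(Cl)c2)CC1)N1C(=O)CCC1=O` is the next member; it differs from compound 2 by chloro in place of methyl on an aromatic carbon, that is, 3-methylphenyl becomes 3-chlorophenyl, the new group standing meta to a large group.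

Among the compounds with values here, no measured step reports a chloro in place of a methyl, so the expectation leans on compound 1 and compound 2 alone. Their step shows that one added group at that aromatic carbon removed the whole effect, which makes a full return to the level of compound 1 unlikely but not excluded. Compound 3 is accordingly expected at about 20%, within a range of 0% to 55%, and the step of a number 20 percentage points higher from compound 2 to compound 3 (beyond the scatter) is estimated as a modest rise.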

Compound 3, a percentage reported as activity, at one dose (the size of the read-out at that dose, not a potency): 50%
Compound 3: middle estimate off by 30 percentage points, on the low side; the range from low to high includes it.
By their numbers in this assay, from the lowest: compound 2; then compounds 1 and 3 (each within the scatter of the next).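

The change from methyl to chloro separates two groups of the same heavy-atom count at one aromatic carbon, meta to a large group, and gives a number 50 percentage points higher from compound 2 to compound 3 (beyond the scatter) in this assay. The collapse seen with compound 2 therefore does not apply to every group placed at this carbon, as the 3-chlorophenyl compound keeps the effect of the unsubstituted core, with no change at the digits printed from compound 1 to compound 3 (within the scatter). No measurement offered here explains why methyl and chloro part so sharply at this position.

The compounds shown leave open whether fluoro, methoxy or an amine at this carbon would keep the effect as chloro does or lose it as methyl does, and whether chloro would give the same result on another carbon of the ring. They also leave open whether compound 1 and compound 3 would still match at other doses or times, since the read-out gives the size of the effect at one dose and not a potency.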